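The source may report more compounds than this note shows. Statements on the series, on what has been measured and on what is new or still open speak of the compounds shown alone.

Measured compounds:
- compound 1, `CC1CCN(C2CCN(S(=O)(=O)c3cccnc3)CC2)CC1`: 2400 nM in a functional assay on DLD-1 cells (Homo sapiens) for antiproliferative activity, read by CellTiter-Glo, with a stated time of 72 h; on this read-out lower numbers stand for stronger inhibition and higher numbers for weaker inhibition
- compound 2, `CC1CCN(C2CCN(S(=O)(=O)c3cnc(Cl)s3)CC2)CC1`: 1800 nM in this assay
- compound 3, `Cc1ccc(S(=O)(=O)N2CCC(N3CCC(C)CC3)CC2)cc1C`: 24 nM in this assay

Compound 3 gives the lowest number of the three. Its nearest neighbour is compound 2, a 75-fold lower number from compound 2 to compound 3 (1.88 log units; beyond the scatter); the furthest is compound 1, a 100-fold lower number from compound 1 to compound 3 (2.00 log units; beyond the scatter). Between compounds 1 and 2 the change is a 1.3-fold lower number from compound 1 to compound 2 (0.12 log units; within the scatter), so the two heteroaryl sulfonyl groups are not separated by the data, while the dimethylphenyl group stands well apart from both.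

Compound 4, `CC1CCN(C2CCN(S(=O)(=O)c3cccc(Cl)c3)CC2)CC1`, has not yet been measured. It differs from compound 3 as follows: 3-chlorophenyl in place of 3,4-dimethylphenyl on a sulfonyl sulfur. Going by the values given here, no measured pair covers a phenyl-for-phenyl exchange; the only steps that bear on this position are the two large ones from heteroaryl to dimethylphenyl, which show that the group on the sulfonyl sulfur can move the number far. Compound 4 keeps a carbocyclic six-membered ring, so a step well short of those is expected, but some loss relative to compound 3 is the more likely direction. The expected step is a 4.2-fold higher number from compound 3 to compound 4 (0.62 log units; beyond the scatter). Compound 4 is estimated at 100 nM in this assay, with a range from 25 nM to 400 nM.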

Compound 4, half-maximal inhibitory concentration: > 5000 nM
Compound 4: a limit, no number; the forecaster's own chance of this, stated with the estimate: 2%; at least 50-fold (1.69 log units) between middle value and limit.
By their numbers in this assay, from the lowest: compound 3; then compounds 2 and 1 (each within the scatter of the next). At a limit, above all of these: compound 4.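

Compound 4 gives a limit of the assay and not a number: the limit of > 5000 nM in this assay, at which 1 of the 4 values shown sits. The exchange of 3,4-dimethylphenyl for 3-chlorophenyl on the sulfonyl sulfur gives an at least 200-fold higher number from compound 3 to compound 4 (2.31 log units; beyond the scatter), so a six-membered aromatic ring of carbon only at this position is not enough to keep the low number of compound 3, and the position responds strongly to a change within the phenyl family as well as to a change of ring type. The 3-chlorophenyl group also compares poorly with the two heteroaryl groups, with an at least 2.7-fold higher number from compound 2 to compound 4 (0.44 log units; beyond the scatter) and an at least 2.0-fold higher number from compound 1 to compound 4 (0.31 log units; beyond the scatter), so the earlier picture of heteroaryl rings against a carbocyclic ring does not hold as a general order, and compound 3 is the only one of the four that reaches a low number.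

This single exchange alters both the ring substituents and their number, so the data do not tell whether the low number of compound 3 depends on the methyl groups or whether the chlorine is what costs activity. An unsubstituted phenyl group, a phenyl ring bearing one methyl, or a dichlorophenyl group would separate these readings.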